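A few compounds are considered here, and "the series" means these few. Any claim that something is new, unique, unknown or untested is made for them only; others in the source may bear on it.

Three compounds have been measured in an ADME assay on microsomes from liver (Mus musculus, strain CD1) for metabolic stability, read by LC-MS, with a stated time of 1 h; a higher number here means that more of the compound is left, a lower number that less of the compound is left:

Compound 1 `O=[N+]([O-])c1cn2c(n1)OC[C@@H](OCc1ccc(-c3ccc(C(F)(F)F)cc3Cl)cc1)C2` gives 93%.
Compound 2 `O=[N+]([O-])c1cn2c(n1)OC[C@@H](OCc1ccc(-c3ccc(OC(F)(F)F)cc3Cl)cc1)C2` gives 86%.
Compound 3 `O=[N+]([O-])c1cn2c(n1)OC[C@@H](OCc1ccc(-c3ccc(Cl)c(OC(F)(F)F)c3)cc1)C2` gives 92%.

Compound 1 and compound 2 differ in one place only: trifluoromethyl in place of trifluoromethoxy on an aromatic carbon. The step this change made is a number 7 percentage points higher from compound 2 to compound 1 (within the scatter), so the two numbers sit close together and no order between them can be read from this assay.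

Compound 3 has the same atoms as compound 2, joined differently; the difference between the two cores is not broken down here. Its value lies close to both of the others, and the gaps to each are within the scatter.

Compound 4 `O=[N+]([O-])c1cn2c(n1)OC[C@@H](OCc1ccc(-c3ccc(Cl)c(C(F)(F)F)c3)cc1)C2` has not yet been measured. It differs from compound 3 in one place: trifluoromethyl in place of trifluoromethoxy on an aromatic carbon. Within the data shown here, this is the same kind of change as the one from compound 2 to compound 1, but the surroundings are not the same: in compound 4 the new group stands ortho to a chloro group and meta to a large group, whereas in compound 1 it stands meta to a chloro group and para to a large group.

Since the same kind of change gave a number 7 percentage points higher from compound 2 to compound 1 (within the scatter), compound 4 is expected to move by about a number 2 percentage points higher from compound 3 to compound 4 (within the scatter) from the value of compound 3, which stays inside the scatter. Compound 4 is therefore estimated at 94%, with a likely range from 85% to 100%.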

Compound 4, percent of the compound remaining: 96%
Beside the measured number, compound 4's estimate is 2 percentage points below it; the range from low to high includes it.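

In this assay, putting trifluoromethyl in place of trifluoromethoxy gives a number 4 percentage points higher from compound 3 to compound 4 (within the scatter). Set beside the earlier case, the same change behaves alike on both cores: the same change on two cores in this assay, a number 7 percentage points higher (within the scatter) from compound 2 to compound 1 and a number 4 percentage points higher (within the scatter) from compound 3 to compound 4, 3 percentage points apart, within the scatter of two such steps. This shows that, in these two pairs, the change can be carried from one core to the other without any step that stands out from the scatter, but it does not show that trifluoromethyl truly raises the number, since neither step can be told apart from repeat-to-repeat variation, and two pairs cannot establish a rule for the whole series or for any other core.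

The compounds shown leave open what happens when the trifluoromethyl or trifluoromethoxy group gives way to a different kind of group, such as an amine, a carboxylic acid or a longer alkyl chain. They also leave open whether the number would stay the same without the chloro group, which all four compounds carry, so the comparison says nothing yet about how much either part of the substitution pattern matters on its own.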